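The source may hold more compounds than are shown below. What is called first, only, known or untested is meant among the compounds shown, and "the series" means these compounds.

Measured so far in an ADME assay on NIH3T3 cells (Mus musculus) for inhibition, read by MTT assay, with a stated time of 48 h; on this read-out lower numbers stand for stronger inhibition and higher numbers for weaker inhibition (all three values are limits of the assay, not numbers):
- compound 1 `Cc1ccc(-c2nc3ccccn3c2Sc2ccccc2)cc1` gives > 100000 nM as a limit
- compound 2 `C(=C/c1nc2ccccn2c1Sc1ccccc1)\c1ccccc1` gives > 100000 nM as a limit
- compound 3 `c1ccc(Sc2c(-c3cccs3)nc3ccccn23)cc1` gives > 100000 nM as a limit

Compound 3 has only a limit, and the whole series stands at the limit of > 100000 nM in this assay, at which 3 of the 3 values shown sit, for now. Compound 4 `Clc1ccc(Sc2c(-c3cccs3)nc3ccccn23)cc1` differs from compound 3 in one place: chloro in place of hydrogen on an aromatic carbon with chloro in place of hydrogen on an aromatic carbon, para to a large group.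

Going by the values given here, no measured step makes this change. The nearest are a step that the two limits leave unreadable from compound 1 to compound 3 and a step that the two limits leave unreadable from compound 2 to compound 3 along with a step that the two limits leave unreadable from compound 1 to compound 2 and all of them concern a different group, so no size can be carried over from them. No step beyond the scatter is therefore expected in this assay and no direction is favoured, with a further limit as the likely report. The expected change is a number no higher from compound 3 to compound 4 (the limit leaves the size open) in this estimate. For compound 4 the estimate is 100000 nM with 35000 nM to 200000 nM as the expected range.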

Compound 4, half-maximal inhibitory concentration: 86100 nM
Compound 4: the middle estimate sits 1.2-fold (0.06 log units) above what was measured; the measured number falls inside the stated range.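

In this assay compound 4 gives 86100 nM as a number and not a limit, and with 4-chlorophenyl in place of phenyl it is the one compound shown that does so. Compound 3 gives > 100000 nM as a limit and so fixes only a floor for the change. The result is an at least 1.1-fold lower number from compound 3 to compound 4 (0.06 log units; that floor lies within the scatter) and does not show chloro at this place moving the read-out beyond the scatter, while the other steps cannot be read and the rest of the series stays at a limit: the limit of > 100000 nM in this assay, at which 3 of the 4 values shown sit.

On these data alone, whether chloro at this place gives a number with the 4-methylphenyl of compound 1 or the 2-phenylethenyl of compound 2 stays open. Also open, as far as these compounds go, is what a methoxy group, an amine or a carboxylic acid at the same place would give.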